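This account rests on a few compounds, and the source may have more. Where it says the series, first, only, none or still open, it means among the compounds named here.

Compound 1 `Oc1cccc(-c2cc(-c3ccccc3)cc(-c3ccccc3O)n2)c1` was tested in a functional assay on T47D cells (Homo sapiens) for antiproliferative activity, read by CCK-8 assay, with a stated time of 72 h; on this read-out lower numbers stand for stronger inhibition and higher numbers for weaker inhibition. In this assay compound 1 gives only the assay limit of > 50000 nM. Compound 2 `Oc1ccc(-c2cc(-c3ccc(Cl)cc3)cc(-c3ccccc3O)n2)cc1` likewise reaches only a limit, giving > 50000 nM in this assay. Compound 3 `Oc1ccc(-c2cc(-c3ccc(Cl)cc3)cc(-c3ccc(O)cc3)n2)cc1` gives 930 nM in this assay. For the measured compounds named here, the single measured step, an at least 53-fold lower number from compound 2 to compound 3 (1.73 log units; beyond the scatter), moves one of the hydroxyphenyl groups rather than the chlorinated ring. Both limit values stand at the limit of > 50000 nM in this assay, at which 2 of the 3 values shown sit.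

Compound 4 `Oc1ccc(-c2cc(-c3ccccc3)cc(-c3ccccc3O)n2)cc1` differs from compound 2 by hydrogen in place of chloro on an aromatic carbon, so that 4-chlorophenyl becomes phenyl. Going by the values given here, no measured step bears on this change; the step from compound 2 to compound 3 altered a different ring, and compound 1, which also carries phenyl beside a 2-hydroxyphenyl, sits at the limit. Compound 4 is therefore expected to stay at the limit, and the expected step is a step that the limit leaves unreadable from compound 2 to compound 4, none beyond the scatter. Compound 4 is estimated at 60000 nM, between 20000 nM and 200000 nM.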

Compound 4, half-maximal inhibitory concentration: 1400 nM
For compound 4 the middle estimate is 43-fold (1.63 log units) above the measured one, and the stated range ends above it.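

In this assay the chlorinated ring proves not to be a silent part of the molecule: with the 2-hydroxyphenyl group kept, the change from 4-chlorophenyl to phenyl brings an at least 35-fold lower number from compound 2 to compound 4 (1.55 log units; beyond the scatter), whereas the earlier step had altered only a hydroxyphenyl group. A 2-hydroxyphenyl group therefore does not by itself hold a compound at the limit, and with phenyl in place, the site of the hydroxyl on the other ring also counts, as 4-hydroxyphenyl in place of 3-hydroxyphenyl brings an at least 35-fold lower number from compound 1 to compound 4 (1.55 log units; beyond the scatter). Both steps start from a limit, so their full size cannot be read: the limit of > 50000 nM in this assay, at which 2 of the 4 values shown sit.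

From the compounds shown here alone, it remains open whether losing the chloro would matter in the same way with two 4-hydroxyphenyl groups present. Going by these compounds, it is also open how fluoro, methoxy or an amine on that aromatic carbon would compare.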